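The source may report more compounds than this note shows. Statements on the series, on what has been measured and on what is new or still open speak of the compounds shown alone.

In a functional assay on HepG2 cells (Homo sapiens) for inhibition, read by MTT assay, with a stated time of 72 h (a higher number here means a weaker inhibitor, a lower number a stronger inhibitor), compound 1 `COc1ccc(/C=C/C(=O)c2c(OC)cc(O)c(CC=C(C)C)c2O)cc1` gives 32400 nM and compound 2 `COc1cc(O)c(CC=C(C)C)c(O)c1C(=O)/C=C/c1cccc([N+](=O)[O-])c1` gives 16600 nM, so compound 2 stands within the usual scatter of compound 1. For the measured compounds named here, the one measured step is a 2.0-fold lower number from compound 1 to compound 2 (0.29 log units; within the scatter), with 3-nitrophenyl in place of 4-methoxyphenyl. Both of these compounds carry the 3-methylbut-2-en-1-yl chain, so this step bears only indirectly on what follows: it shows no change beyond the scatter, but at a different place in the structure.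

Compound 3 `COc1cc(O)cc(O)c1C(=O)/C=C/c1cccc([N+](=O)[O-])c1` keeps the 3-nitrophenyl of compound 2 and has hydrogen in place of 3-methylbut-2-en-1-yl on an aromatic carbon, ortho to two hydroxy groups and para to a methoxy group: hydrogen in place of 3-methylbut-2-en-1-yl on an aromatic carbon. Going by the values given here, no measured compound lacks this chain, so the data give no direct size for such a step. A modest move toward a higher number in this assay is expected, though a result within the scatter would be no surprise. The expected step is a 2.1-fold higher number from compound 2 to compound 3 (0.32 log units; beyond the scatter). For compound 3, the estimated value is 35000 nM, with an expected range from 14000 nM to 90000 nM.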

Compound 3, half-maximal inhibitory concentration: 16300 nM
Beside the measured number, compound 3's estimate is 2.1-fold (0.33 log units) above it; the measured number falls inside the stated range.
By their numbers in this assay, from the lowest: compounds 3, 2 and 1 (each within the scatter of the next).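

In this assay this aromatic carbon, ortho to two hydroxy groups and para to a methoxy group, now has a direct reading: hydrogen in place of 3-methylbut-2-en-1-yl gives a 1.0-fold lower number from compound 2 to compound 3 (0.01 log units; within the scatter) and the chain is thus shown to be dispensable for the level of the number when the 3-nitrophenyl is present. The earlier step changed only the other place in the structure and said nothing about this chain, whereas this one shows that losing the whole chain, with its one double bond, leaves the read-out within the scatter. No measured information at hand explains why the number stays where it does.

The compounds shown leave open whether the chain is equally dispensable with 4-methoxyphenyl in place of 3-nitrophenyl, and whether another group on this aromatic carbon, such as a longer chain, an amine or a carboxylic acid, would give a number beyond the scatter of compound 3. Since each of the three compounds lies within the scatter of the next, they also do not show which change at either place could move the number beyond it.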